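Methyl for Fluoro on Two Related Cores

This account rests on a few compounds, and the source may have more. Where it says the series, first, only, none or still open, it means among the compounds named here.

Measured compounds:
Compound 1, `CCO[C@H]1C[C@@H](c2coc3ccc(F)cc3c2=O)N(c2ccccc2)O1`, gives > 60000 nM in a functional assay on THP-1 cells (Homo sapiens) for inhibition, read by sulforhodamine B assay, with a stated time of 48 h (on this read-out higher numbers stand for weaker inhibition and lower numbers for stronger inhibition), which is a limit of the assay and not a number.
Compound 2, `O=C1[C@H]2[C@H](ON(c3ccccc3)[C@@H]2c2coc3ccc(F)cc3c2=O)C(=O)N1c1ccccc1`, gives 43500 nM.
Compound 3, `CCO[C@H]1C[C@@H](c2coc3ccc(C)cc3c2=O)N(c2ccccc2)O1`, gives 41000 nM.

Compound 1 sits at the limit of > 60000 nM in this assay, at which 1 of the 3 values shown sits. Compound 3 differs from compound 1 by methyl in place of fluoro on an aromatic carbon, and the step is an at least 1.4-fold lower number from compound 1 to compound 3 (0.16 log units; that floor lies within the scatter). The values of compound 2 and compound 3 lie within the usual scatter of each other, so no order between them can be drawn. How the core of compound 2 differs from the core of compound 1 is not broken down here.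

Compound 4, `Cc1ccc2occ([C@@H]3[C@H]4C(=O)N(c5ccccc5)C(=O)[C@H]4ON3c3ccccc3)c(=O)c2c1`, has not yet been measured. It differs from compound 2 by methyl in place of fluoro on an aromatic carbon, the same change, at the same place, as that from compound 1 to compound 3. Among the measured compounds shown here, a similar step is expected in this assay because an at least 1.4-fold lower number from compound 1 to compound 3 (0.16 log units; that floor lies within the scatter) is the only precedent, and it is small. Compound 4 is therefore expected to give 35000 nM, estimated to lie between 15000 nM and 80000 nM. The expected step is a 1.2-fold lower number from compound 2 to compound 4 (0.09 log units; within the scatter).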

Compound 4, half-maximal inhibitory concentration: > 60000 nM
Compound 4: a limit, no number; the forecaster's own chance of this, stated with the estimate: 25%; middle value at least 1.7-fold (0.23 log units) from the limit.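

In this assay compound 4 gives > 60000 nM, which is a limit of the assay and not a number. On the core shared with compound 2, methyl in place of fluoro on an aromatic carbon gives an at least 1.3-fold higher number from compound 2 to compound 4 (0.13 log units; that floor lies within the scatter), so the step has a floor but no measured size. Set beside the earlier step, this shows no dependable carry-over of the change from one core to the other, and it does not show that the two cores respond differently either: the same change on two cores in this assay, an at least 1.4-fold lower number (0.16 log units; that floor lies within the scatter) from compound 1 to compound 3 and an at least 1.3-fold higher number (0.13 log units; that floor lies within the scatter) from compound 2 to compound 4; the limit leaves it open whether they differ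

On these data alone, the limit also restricts what can be read across the whole set: the limit of > 60000 nM in this assay, at which 2 of the 4 values shown sit. It remains open whether another group on that aromatic carbon, such as chloro, methoxy or an amine, would give values clear of this limit on either core, and whether such a group would then produce a step that could be compared between the two cores.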